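A further methoxy on compound 1

The source may hold more compounds than are shown below. What is called first, only, known or untested is meant among the compounds shown, and "the series" means these compounds.

Measured so far in a functional assay on the whole organism (strain Kunming) with Mus musculus as the target, in the formalin test, with a stated time of 0.5 h; on this read-out higher numbers stand for an effect only at larger amounts of compound and lower numbers for an effect already at smaller amounts
- compound 1 `COc1cc(OC)c(OC)cc1/C=C/COC(=O)/C=C/c1ccc(OC)c(OC)c1` gives 225 umol/kg
- compound 2 `COc1cc(OC)c(OC)cc1/C=C/COC(=O)/C=C/c1ccc(Br)cc1` gives 243 umol/kg

Going by the values given here, on these numbers compound 1 cannot be separated from compound 2, its only neighbour. Compound 3 `COc1cc(OC)c(OC)cc1/C=C/COC(=O)/C=C/c1cc(OC)c(OC)c(OC)c1` differs from compound 1 by methoxy in place of hydrogen on an aromatic carbon on the 3,4-dimethoxyphenyl group. Among the compounds with values here, the only measured step is a 1.1-fold higher number from compound 1 to compound 2 (0.03 log units; within the scatter) and it replaces that same group, so no step beyond the scatter is expected in this assay for compound 3. Compound 3 is expected at 220 umol/kg within an estimated range of 110 umol/kg to 430 umol/kg on this read-out. That estimate amounts to a 1.0-fold lower number from compound 1 to compound 3 (0.01 log units; within the scatter) as the expected step.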

Compound 3, dose for half-maximal effect: 192 umol/kg
Beside the measured number, compound 3's estimate is 1.1-fold (0.06 log units) above it; the measured number falls inside the stated range.
By their numbers in this assay, from the lowest: compounds 3, 1 and 2 (each within the scatter of the next).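

In this assay the added methoxy gives a 1.2-fold lower number from compound 1 to compound 3 (0.07 log units; within the scatter) and so adds a single-place change on this aromatic carbon, ortho to a methoxy group, to the earlier replacement of the whole group. Adding this methoxy at this position therefore produces no step beyond the scatter. No measurement here offers an explanation for this result. The compounds shown leave open whether an amine or a carboxylic acid on this same aromatic carbon, or a longer chain in place of the methoxy, would give a step beyond the scatter.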